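This account rests on a few compounds, and the source may have more. Where it says the series, first, only, none or still open, it means among the compounds named here.

Working notes on the series. Compound 1 `CCCNc1ncnc2c1cnn2-c1ccccc1`, compound 2 `Cc1nc(NC(C)C)c2cnn(-c3ccccc3)c2n1` and compound 3 `CCCCNc1nc(C)nc2c1cnn2-c1ccccc1` share one core and differ in the substituent on the amino nitrogen and in the presence of the methyl. In a functional assay on G-361 cells (Homo sapiens) for cytotoxicity, read by sulforhodamine B assay (on this read-out higher numbers stand for weaker inhibition of growth and lower numbers for stronger inhibition of growth), compound 1 gives > 100000 nM, which is a limit of the assay and not a number (the limit of > 100000 nM in this assay, at which 1 of the 3 values shown sits). In this assay compound 2 gives 32000 nM. In this assay, going by the values given here, compound 3 gives 2400 nM, the lowest of the two numbers available; the only single-point step measured so far is a 13-fold lower number from compound 2 to compound 3 (1.12 log units; beyond the scatter), so a change of the alkyl on that nitrogen has moved the read-out substantially.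

Compound 4 `CCN(CC)c1nc(C)nc2c1cnn2-c1ccccc1` is the next case: diethylamino in place of butylamino on an aromatic carbon. The measured step from compound 2 to compound 3 bears on it only partly, as that step kept the hydrogen-bond donor and changed only the shape of the alkyl, whereas here the donor is lost and the same carbons are split onto the nitrogen. Among the compounds with values here, no measured step covers loss of that donor. The expectation is therefore a weaker effect than compound 3, with compound 4 estimated at 20000 nM in this assay, within a range of 4000 nM to 100000 nM, corresponding to an expected step of an 8.3-fold higher number from compound 3 to compound 4 (0.92 log units; beyond the scatter).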

Compound 4, concentration for 50% growth inhibition: > 100000 nM
Compound 4 was reported as a limit (the forecaster's own chance of this, stated with the estimate: 25%); middle value at least 5.0-fold (0.69 log units) from the limit.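

The two groups on this aromatic carbon have the same atoms joined differently, and the counted difference is the hydrogen-bond donor on butylamino, which diethylamino lacks; this rearrangement alone gives an at least 41-fold higher number from compound 3 to compound 4 (1.61 log units; beyond the scatter), so the read-out here depends on more than the atoms present in the group. The comparison with the branched group points the same way, with an at least 3.1-fold higher number from compound 2 to compound 4 (0.49 log units; beyond the scatter), which places diethylamino on the weaker side of both isopropylamino and butylamino on the methyl-bearing core. In this assay, the reading for compound 4 is a limit and not a number: the limit of > 100000 nM in this assay, at which 2 of the 4 values shown sit.

The compounds shown do not separate the missing donor from the splitting of the carbons onto the nitrogen, and a tertiary amine that keeps the butyl chain intact, such as N-methylbutylamino, or a cyclic amine such as pyrrolidine, would bear on that question. From the compounds shown here alone, it also remains open whether a longer chain such as hexylamino extends the gain seen with butylamino, or whether that gain has already reached its limit.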